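Adding a Trifluoromethyl Group to the Benzyl Ring of Compound 1

This account rests on a few compounds, and the source may have more. Where it says the series, first, only, none or still open, it means among the compounds named here.

Compound 1, `COc1cc(OC)c(-c2coc3cc(OCc4ccccc4)ccc3c2=O)cc1OC`, in a functional assay on U-251 cells (Homo sapiens) for antiproliferative activity, read by MTT assay, with a stated time of 24 h; a lower number here means a stronger inhibitor, a higher number a weaker inhibitor: 6750 nM
Compound 2, `COc1cc(OC)c(-c2coc3cc(OCc4ccccc4F)ccc3c2=O)cc1OC`, in this assay: 2890 nM
Compound 3, `COc1cc(OC)c(-c2coc3cc(OCc4ccccc4C#N)ccc3c2=O)cc1OC`, in this assay: 980 nM

Among these three, compound 1 gives the highest number, so it is the weakest inhibitor of the set. Its nearest neighbour is compound 2: a 2.3-fold lower number from compound 1 to compound 2 (0.37 log units; beyond the scatter). The furthest is compound 3: a 6.9-fold lower number from compound 1 to compound 3 (0.84 log units; beyond the scatter). Between the two substituted compounds, a 2.9-fold lower number from compound 2 to compound 3 (0.47 log units; beyond the scatter).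

Compound 4, `COc1cc(OC)c(-c2coc3cc(OCc4ccc(C(F)(F)F)cc4)ccc3c2=O)cc1OC`, is the next step from compound 1: trifluoromethyl in place of hydrogen on an aromatic carbon. The two measured steps both put a small group onto the same benzyl ring of compound 1, and both lowered the number, modestly. Among the compounds with values here, the trifluoromethyl group is a different group at a different place on that ring, and no measured step involves it, so the parallel is loose. A modest lowering is still the more likely direction, and the expected step is a 2.5-fold lower number from compound 1 to compound 4 (0.40 log units; beyond the scatter). For compound 4 in this assay the estimate is 2700 nM, with a range from 900 nM to 8000 nM.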

Compound 4, half-maximal inhibitory concentration: 3750 nM
Estimate against measurement, compound 4: 1.4-fold (0.14 log units) below; the range from low to high includes it.
By their numbers in this assay, from the lowest: compound 3; then compounds 2, 4 and 1 (each within the scatter of the next, the first and the last beyond it).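

In this assay, the trifluoromethyl group, para to a large group on the benzyl ring, gives a step that stays within the scatter: a 1.8-fold lower number from compound 1 to compound 4 (0.26 log units; within the scatter). So a new group on this ring does not always move the number beyond the scatter, as the fluoro and cyano steps did. Among the substituted compounds the result splits, with a 1.3-fold higher number from compound 2 to compound 4 (0.11 log units; within the scatter), against a 3.8-fold higher number from compound 3 to compound 4 (0.58 log units; beyond the scatter); both of these steps change the group and also its place on the ring.

No available evidence explains why these steps differ in size. The compounds shown leave open whether the group or its place matters more, as none carries the same group at two places on the ring, and how an amine or a carboxylic acid on this ring would behave.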